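The source may hold more compounds than are shown below. What is called first, only, known or untested is meant among the compounds shown, and "the series" means these compounds.

Measured compounds:
Compound 1, `C#CCSc1nc(Nc2cccc(Cl)c2)c(C#N)c(-c2ccccc2)n1`: in a functional assay on MGC-803 cells (Homo sapiens) for inhibition, read by MTT assay, with a stated time of 72 h (a lower number here means a stronger inhibitor, a higher number a weaker inhibitor), compound 1 reaches only the limit > 128000 nM.
Compound 2, `N#Cc1c(Nc2ccccc2Cl)nc(SCc2cn(Cc3ccccc3Cl)nn2)nc1-c1ccccc1`: in this assay compound 2 gives 4640 nM.

Going by the values given here, compound 2 holds the only actual number in this set; the value for compound 1 is a limit of the assay and not a number, as the limit of > 128000 nM in this assay, at which 1 of the 2 values shown sits, records. Compound 3, `N#Cc1c(Nc2ccccc2F)nc(SCc2cn(Cc3ccccc3Cl)nn2)nc1-c1ccccc1`, has not yet been measured in this assay. It differs from compound 2 in one place: fluoro in place of chloro on an aromatic carbon. Among the compounds with values here, no step between two measured compounds is available here, so there is no measured guide to what this exchange does. Putting fluoro in place of chloro on an aromatic carbon is expected to shift this assay only modestly, perhaps towards a somewhat weaker inhibitor, and the expected step is a 1.4-fold higher number from compound 2 to compound 3 (0.15 log units; within the scatter), within or only just beyond the usual scatter. Compound 3 is therefore estimated at 6500 nM, with a range from 2000 nM to 22000 nM.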

Compound 3, half-maximal inhibitory concentration: 7580 nM
The estimate for compound 3 lay 1.2-fold (0.07 log units) below the measured number; the range from low to high includes it.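

In this assay, going by these compounds alone, replacing the 2-chlorophenyl group with the 2-fluorophenyl group gives a 1.6-fold higher number from compound 2 to compound 3 (0.21 log units; within the scatter) as the only measured step at this position. On this aromatic carbon, ortho to a large group, the assay therefore does not tell fluoro and chloro apart, and the smaller halogen serves as well as the larger one. No measurement shown here gives a reason for this result.

Going by these compounds, a single pair of halogens cannot show whether this position accepts other kinds of group, so the effect of a methoxy group, an amine or a carboxylic acid on the same carbon remains open. Also open, on these data alone, is whether the same exchange would give a similar result on the other chloro-bearing ring of compound 2.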